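The compounds below may be only part of what the source reports. "The series", "measured", "known", "first", "only" and "open" are said of these compounds alone.

Measured so far:
Compound 1, `CC(C)CNc1nc(N)nc2c1ncn2/C=C1/CC1(CO)CO`: in an ADME assay on BCBL1 cells (Homo sapiens) for cytotoxicity, with a stated time of 7 days (on this read-out higher numbers stand for lower toxicity in this test and lower numbers for higher toxicity in this test), compound 1 gives > 20000 nM, which is a limit of the assay and not a number.
Compound 2, `Nc1nc(NC2CCCC2)c2ncn(/C=C3/CC3(CO)CO)c2n1`: in this assay compound 2 gives 71700 nM.

Compound 1 stands only at a limit, because the limit of > 20000 nM in this assay, at which 1 of the 2 values shown sits, leaves its true value open, and for that reason the step that the limit leaves unreadable from compound 1 to compound 2 cannot be sized. Compound 3, `Nc1nc(OCc2ccccc2)c2ncn(/C=C3/CC3(CO)CO)c2n1`, has not been measured. It differs from compound 1 by benzyloxy in place of isobutylamino on an aromatic carbon. Going by the values given here, the only measured step touches the same group but its size is unreadable, so it gives neither direction nor size; both measured values lie at the high end of this assay. The estimate therefore means a step that the limit leaves unreadable from compound 1 to compound 3, expected to lie within the scatter, with a fair chance that only a limit is reported again. Compound 3 is estimated at 40000 nM, with a range from 15000 nM to 120000 nM.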

Compound 3, half-maximal cytotoxic concentration: > 20000 nM
Compound 3: only a limit was reported (the forecaster's own chance of this, stated with the estimate: 55%); the middle value lies beyond the limit too.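

No new step can be read from compound 3 to compound 1 or compound 2, because the comparison rests on a limit: the limit of > 20000 nM in this assay, at which 2 of the 3 values shown sit. The compounds shown leave open where the true values of compound 1 and compound 3 lie in this assay, and whether benzyloxy and isobutylamino differ there.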